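The compounds below may be only part of what the source reports. "The series", "measured", "known", "first", "only" and "open" are said of these compounds alone.

Of the compounds shown here, three built on one shared core have been measured in a functional assay on HeLa cells (Homo sapiens) for cytotoxicity, read by MTT assay, with a stated time of 24 h; on this read-out higher numbers stand for weaker inhibition and lower numbers for stronger inhibition. Compound 1, `O=C(NC(=S)Nc1nc2cc([N+](=O)[O-])ccc2s1)c1ccccc1`, gives 75100 nM. Compound 2, `Nc1ccc2sc(NC(=S)NC(=O)c3ccccc3)nc2c1`, gives 70100 nM, and compound 3, `O=C(NC(=S)Nc1nc2ccccc2s1)c1ccccc1`, gives 57500 nM. Compound 1 lies within the scatter of both neighbours: a 1.1-fold lower number from compound 1 to compound 2 (0.03 log units; within the scatter) and a 1.3-fold lower number from compound 1 to compound 3 (0.12 log units; within the scatter). The remaining pair is alike: a 1.2-fold lower number from compound 2 to compound 3 (0.09 log units; within the scatter).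

Compound 4, `O=C(NC(=S)Nc1nc2cc([N+](=O)[O-])ccc2s1)c1ccc([N+](=O)[O-])cc1`, has not been measured. It differs from compound 1 in one place: nitro in place of hydrogen on an aromatic carbon.

For the measured compounds named here, none of the measured steps touches this ring. All three concern the group on the aromatic carbon of the shared core, swapping nitro, amino and hydrogen, and each of them stayed within the scatter. The closest analogy is the step from compound 3 to compound 1, where hydrogen gave way to nitro on the other ring of the core and the number barely moved. There is no measured case of a nitro entering the phenyl ring, so the expectation rests on that analogy alone: a step of a 1.0-fold lower number from compound 1 to compound 4 (0.00 log units; within the scatter) is expected, that is, no change beyond the scatter.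

Compound 4 is therefore estimated to give 75000 nM in this assay, with a likely range from 35000 nM to 160000 nM.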

Compound 4, half-maximal inhibitory concentration: 68500 nM
Estimate against measurement, compound 4: 1.1-fold (0.04 log units) above, within the range that was stated.
By their numbers in this assay, from the lowest: compounds 3, 4, 2 and 1 (each within the scatter of the next).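

In this assay, for the compounds shown here, the earlier compounds varied only the group on the aromatic carbon of the shared core, whereas here the phenyl ring itself becomes 4-nitrophenyl, with the new group para to a large group, and the result is a 1.1-fold lower number from compound 1 to compound 4 (0.04 log units; within the scatter) within a single change. Going by these compounds alone, this gives the first reading for this ring, and in this one case a nitro placed there brings no change beyond the scatter, the same outcome as the nitro, amino and hydrogen swaps on the core. Nothing available explains why the number stays put, so the result stands as an observation only.

Going by these compounds, a single nitro says little about this ring as a whole, so it remains open whether an amine, a methoxy group or a carboxylic acid in the same place would also leave the number within the scatter. On these data alone, it is also open whether 4-nitrophenyl would behave the same way on the core of compound 2 or compound 3, where the group on the core is amino or hydrogen rather than nitro.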